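Benzyl Group Returned to the Sulfur: Expecting Compound 4

The compounds below may be only part of what the source reports. "The series", "measured", "known", "first", "only" and "open" are said of these compounds alone.

Measured in an assay for binding affinity to high affinity nerve growth factor receptor (Homo sapiens), read by polymerase chain reaction; on this read-out lower numbers stand for tighter binding and higher numbers for weaker binding:
compound 1 `Cc1cc(Nc2cc(N3CCN(C)CC3)nc(SCc3ccc(F)cc3)n2)n[nH]1` gives 1 nM
compound 2 `Cc1cc(Nc2cc(N3CCN(C)CC3)nc(Sc3ccccc3)n2)n[nH]1` gives 31.6 nM
compound 3 `CN1CCN(c2cc(Nc3cc(C4CCCC4)[nH]n3)nc(Sc3ccccc3)n2)CC1` gives 1.59 nM

Compound 2 stands highest of the three numbers; compound 3 is its nearest neighbour, with a 20-fold lower number from compound 2 to compound 3 (1.30 log units; beyond the scatter), and compound 1 its furthest. Compound 4 `Cc1ccc(CSc2nc(Nc3cc(C)[nH]n3)cc(N3CCN(C)CC3)n2)cc1` differs from compound 2 by 4-methylbenzyl in place of phenyl on a sulfur. The step that bears on this is a 32-fold higher number from compound 1 to compound 2 (1.50 log units; beyond the scatter), a large change in the same place run in the opposite direction; the step from compound 2 to compound 3 touches a different place and informs it only loosely. A large step downward is therefore expected, a 21-fold lower number from compound 2 to compound 4 (1.32 log units; beyond the scatter). Compound 4 is estimated at 1.5 nM, within 0.5 nM to 5 nM.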

Compound 4, dissociation constant: 3.98 nM
The estimate for compound 4 lay 2.7-fold (0.42 log units) below the measured number; low and high end bracket the measured number.
By their numbers in this assay, from the lowest: compounds 1 and 3 (each within the scatter of the next); then compound 4; then compound 2.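

In this assay the change to 4-methylbenzyl on the sulfur brings a 7.9-fold lower number from compound 2 to compound 4 (0.90 log units; beyond the scatter), so the lower number seen with the 4-fluorobenzyl of compound 1 is not confined to that one benzyl group. The group on the benzyl ring also counts, since methyl in place of fluoro gives a 4.0-fold higher number from compound 1 to compound 4 (0.60 log units; beyond the scatter). No measurement shown accounts for either step.

On these data alone, whether an unsubstituted benzyl or a longer chain such as phenylethyl on the sulfur would follow compound 4 stays open. So does whether the cyclopentyl of compound 3 would combine with a benzyl group on the sulfur.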